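Swapping the urea for a butanamide on the sulfonyl nitrogen

The source may report more compounds than this note shows. Statements on the series, on what has been measured and on what is new or still open speak of the compounds shown alone.

Compounds measured so far:
compound 1 `CC(C)Cc1cc(-c2cccc(Cn3ccnc3)c2)c(S(=O)(=O)NC(=O)OC2CCCC2)s1`, 180 nM
compound 2 `CCN(CC)C(=O)NS(=O)(=O)c1sc(CC(C)C)cc1-c1cccc(Cn2ccnc2)c1`, 2300 nM

Both compounds were tested in an assay on HEK293 cells for displacement of a labelled ligand from Type-2 angiotensin II receptor (Homo sapiens), read by scintillation counting, with a stated time of 240 min; a higher number here means a weaker inhibitor, a lower number a stronger inhibitor. Compound 2 stands at the higher of the two numbers, so it is the weaker binder of the pair, since the step of a 13-fold higher number from compound 1 to compound 2 (1.11 log units; beyond the scatter) lies beyond the usual scatter.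

Compound 3 `CCCC(=O)NS(=O)(=O)c1sc(CC(C)C)cc1-c1cccc(Cn2ccnc2)c1` has not yet been measured. It differs from compound 2 in one place: propyl in place of diethylamino on a carbonyl carbon. Going by the values given here, the only step on record that touches this position is the one from cyclopentyloxy to diethylamino, a 13-fold higher number from compound 1 to compound 2 (1.11 log units; beyond the scatter), which was large. That step shows that the group on this carbonyl carbon matters, but it does not show how a propyl chain will compare with a diethylamino group. Among the compounds with values here, no compound with a plain alkyl chain here has been measured. The expectation is therefore uncertain and rests on the size of the known step alone.

With that caution, compound 3 is estimated at 600 nM, within a range of 150 nM to 2500 nM, which would mean an expected step of a 3.8-fold lower number from compound 2 to compound 3 (0.58 log units; beyond the scatter).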

Compound 3, inhibition constant: 300 nM
Beside the measured number, compound 3's estimate is 2.0-fold (0.30 log units) above it, within the range that was stated.
By their numbers in this assay, from the lowest: compounds 1 and 3 (each within the scatter of the next); then compound 2.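

In this assay, the change to propyl on the carbonyl carbon gives a 7.7-fold lower number from compound 2 to compound 3 (0.88 log units; beyond the scatter), so the large loss seen with diethylamino is not a general result of moving away from cyclopentyloxy. The comparison with the first compound gives a 1.7-fold higher number from compound 1 to compound 3 (0.22 log units; within the scatter) and lies within the usual scatter, so these data cannot separate propyl, an open chain with no ring, from cyclopentyloxy, which carries one; among these three compounds, diethylamino is the group that stands apart. No supporting measurement is available to explain why this group behaves differently from the other two.

Diethylamino and propyl differ both in their size and in the nitrogen that diethylamino places on the carbonyl carbon, so these compounds cannot show which of the two differences matters. Methylamino, a smaller group that keeps that nitrogen, and pentyl, a longer chain with none, would each pull those two differences apart, and how either would stand at this position remains open.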